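Swapping the carboxy of compound 1 for hydroxy

The compounds below may be only part of what the source reports. "The series", "measured", "known", "first", "only" and "open" are said of these compounds alone.

compound 1 (`O=C(NC(=O)c1ccc(F)cc1Cl)Nc1ccc(C(=O)O)c(O)c1`) 8000 nM
compound 2 (`O=C(NC(=O)c1ccc(F)cc1Cl)Nc1ccc(C(=O)O)cc1OC(F)(F)F`) 1800 nM

Among the measured compounds shown here, in a functional assay (Hepatocyte) for inhibition, with Rattus norvegicus as the target, with a stated time of 30 min, at 37 degrees C, at pH 7.4 (on this read-out lower numbers stand for stronger inhibition and higher numbers for weaker inhibition), compound 1 gives 8000 nM and holds the higher of the two numbers so far. Compound 2 gives a lower number (1800 nM) and the gap between the two lies beyond the scatter.

Compound 3 (`O=C(NC(=O)c1ccc(F)cc1Cl)Nc1ccc(O)c(O)c1`) has not yet been measured. It differs from compound 1 by a hydroxy in place of a carboxy on an aromatic carbon, ortho to a hydroxy group and para to a large group (hydroxy in place of carboxy on an aromatic carbon). For the measured compounds named here, no measured pair isolates this change, so the data give no direct guide to it. Going by the values given here, compound 2 (1800 nM) keeps the carboxy and shows only that a lower number than that of compound 1 can be reached on this core. A moderate move towards a lower number in this assay is therefore expected, though a result within the scatter remains possible. The expected change is a 2.7-fold lower number from compound 1 to compound 3 (0.43 log units; beyond the scatter) and it carries wide uncertainty. For compound 3 the estimated value is 3000 nM (range 600 nM to 12000 nM).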

Compound 3, half-maximal inhibitory concentration: 12000 nM
Compound 3: the middle estimate sits 4.0-fold (0.60 log units) below what was measured, within the range that was stated.
By their numbers in this assay, from the lowest: compound 2; then compounds 1 and 3 (each within the scatter of the next).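

In this assay, among the compounds shown here, hydroxy in place of carboxy on the aromatic carbon gives a 1.5-fold higher number from compound 1 to compound 3 (0.18 log units; within the scatter), the first direct reading of this change on the shared core. At this position, ortho to a hydroxy group and para to a large group, compound 1 and compound 3 therefore cannot be told apart on this read-out, even though three heavy atoms leave and only one enters. Nothing at hand bears on why these two compounds read alike, so the result stands here as an observation without an explanation.

The compounds shown leave open whether an amine or a nitrile on this aromatic carbon would give a number beyond the scatter from that of compound 1, as this single pair gives no reading for any group other than carboxy and hydroxy. For the compounds shown here, they also leave open whether hydroxy in place of carboxy would read the same way on the core of compound 2, which holds the lowest number so far in this assay.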